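From hydroxymethyl to 2-(dimethylamino)ethyl on the aromatic nitrogen

The source may report more compounds than this note shows. Statements on the series, on what has been measured and on what is new or still open speak of the compounds shown alone.

In a functional assay on KB cells (Homo sapiens) for inhibition, with a stated time of 72 h (on this read-out lower numbers stand for stronger inhibition and higher numbers for weaker inhibition), compound 1 (`CCCn1ccc2cc(C(=O)c3cc(OC)c(OC)c(OC)c3)ccc21`) gives 1900 nM and compound 2 (`COc1cc(C(=O)c2ccc3c(ccn3C(C)C)c2)cc(OC)c1OC`) gives 1800 nM here, and a 1.1-fold lower number from compound 1 to compound 2 (0.02 log units; within the scatter) separates them. Compound 3 (`COc1cc(C(=O)c2ccc3c(ccn3CO)c2)cc(OC)c1OC`) stands lowest of the three at 39 nM here, with a 49-fold lower number from compound 1 to compound 3 (1.69 log units; beyond the scatter) and a 46-fold lower number from compound 2 to compound 3 (1.66 log units; beyond the scatter) as its large steps. In compound 4 (`COc1cc(C(=O)c2ccc3c(ccn3CCN(C)C)c2)cc(OC)c1OC`), (dimethylamino)methyl sits in place of hydroxy on a saturated chain carbon bound to an aromatic nitrogen ((dimethylamino)methyl in place of hydroxy on a saturated chain carbon bound to an aromatic nitrogen). Among the measured compounds shown here, no measured compound carries this new group. Compound 1 and compound 2 also lack the hydroxy, however, and both lie far higher, so a large rise is expected in this assay that may fall somewhat short of those steps. The expected step is a 23-fold higher number from compound 3 to compound 4 (1.36 log units; beyond the scatter) overall. Compound 4 is estimated at 900 nM within a range of 150 nM to 4000 nM overall.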

Compound 4, half-maximal inhibitory concentration: 5200 nM
For compound 4 the middle estimate is 5.8-fold (0.76 log units) below the measured one; the whole stated range lies below it.
By their numbers in this assay, from the lowest: compound 3; then compounds 2 and 1 (each within the scatter of the next); then compound 4.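

In this assay, putting 2-(dimethylamino)ethyl at this place in place of hydroxymethyl gives a 130-fold higher number from compound 3 to compound 4 (2.12 log units; beyond the scatter) and removes the whole gain seen with hydroxymethyl. The new chain also falls modestly behind both plain carbon chains, with a 2.9-fold higher number from compound 2 to compound 4 (0.46 log units; beyond the scatter) and a 2.7-fold higher number from compound 1 to compound 4 (0.44 log units; beyond the scatter) as its steps, so its dimethylamino end is worse here than having no such group. No measurement shown explains these steps.

Left open is whether the hydroxy needs to sit on the carbon bound to the aromatic nitrogen, which a 2-hydroxyethyl group would test. An aminomethyl group would show whether an amine on that same carbon can match hydroxymethyl.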